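The source may report more compounds than this note shows. Statements on the series, on what has been measured and on what is new or still open speak of the compounds shown alone.

Compound 1 `Cc1cc2ccccc2nc1-c1cn(-c2ccc(F)cc2)nn1` was tested in a functional assay on THP-1 cells (Homo sapiens) for cytotoxicity, read by MTT assay, with a stated time of 24 h (on this read-out lower numbers stand for stronger inhibition and higher numbers for weaker inhibition), and gives > 100 ug/mL, a limit of the assay rather than a number. Compound 2 `CCCCCCCCCCn1cc(-c2nc3ccccc3cc2CCC)nn1` gives > 100 ug/mL, likewise a limit. Compound 3 `CCCCCc1cc2ccccc2nc1-c1cn(-c2ccc(F)cc2)nn1` gives > 100 ug/mL, again a limit.

Compound 3 therefore stands at the limit, where all three values shown sit (the limit of > 100 ug/mL in this assay, at which 3 of the 3 values shown sit). Among the measured compounds shown here, the only single-change step leading to it, a step that the two limits leave unreadable from compound 1 to compound 3, cannot be read because the limit of > 100 ug/mL in this assay, at which 3 of the 3 values shown sit, bounds both of its ends. Compound 4 `CCc1cc2ccccc2nc1-c1cn(-c2ccc(F)cc2)nn1` differs from compound 3 by hydrogen in place of propyl on a saturated chain carbon, two bonds along the chain from an aromatic carbon. For the measured compounds named here, no measured step offers a readable size, so in this assay no step beyond the scatter is expected, and the estimated step that the limit leaves unreadable from compound 3 to compound 4 is set to stay within it. Compound 4 is expected to give 150 ug/mL, between 60 ug/mL and 400 ug/mL, and is expected to return as a limit once more.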

Compound 4, half-maximal inhibitory concentration: > 100 ug/mL
Compound 4 was reported as a limit; the forecaster's own chance of this, stated with the estimate: 85%; the middle value is on the limit's open side.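

In this assay no new step can be read among compound 1, compound 3 and compound 4, as each value is a limit: the limit of > 100 ug/mL in this assay, at which 4 of the 4 values shown sit.

Going by these compounds, how far these compounds lie beyond that limit, and whether changing the chain shifts their cytotoxicity, stays open.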